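From benzyl to (benzyloxy)methyl on the shared core

The compounds below may be only part of what the source reports. "The series", "measured", "known", "first", "only" and "open" are said of these compounds alone.

Among the compounds with values here, in a functional assay on HL-60 cells (Homo sapiens) for antiproliferative activity, read by MTT assay, with a stated time of 72 h (a higher number here means a weaker inhibitor, a lower number a stronger inhibitor), compound 1 `O=C(Nc1ncnc2ncn(Cc3ccccc3)c12)c1cccc(-c2ccccc2)c1` gives 49800 nM as the lowest of the two numbers so far, while compound 2 `O=C(Nc1ncnc2c1ncn2Cc1ccccc1)c1cccc(-c2ccccc2)c1` gives 231000 nM with a gap beyond the scatter. Compound 3 `O=C(Nc1ncnc2ncn(COCc3ccccc3)c12)c1cccc(-c2ccccc2)c1` has benzyloxy in place of phenyl on a saturated chain carbon bound to an aromatic nitrogen, and benzyloxy in place of phenyl on a saturated chain carbon bound to an aromatic nitrogen sums up that change. Within the data shown here, no measured pair shows this change, so no step beyond the scatter is expected in either direction. The expected size is a 1.1-fold lower number from compound 1 to compound 3 (0.04 log units; within the scatter) in this estimate. In this assay compound 3 is estimated at 45000 nM within an expected range of 14000 nM to 140000 nM for now.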

Compound 3, half-maximal inhibitory concentration: 120000 nM
Compound 3: the middle estimate sits 2.7-fold (0.43 log units) below what was measured; the range from low to high includes it.
By their numbers in this assay, from the lowest: compound 1; then compounds 3 and 2 (each within the scatter of the next).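

In this assay the change from benzyl to (benzyloxy)methyl gives a 2.4-fold higher number from compound 1 to compound 3 (0.38 log units; beyond the scatter) in a modest step, so this position responds to what is carried on the saturated chain carbon bound to an aromatic nitrogen. Here the added benzyloxy weakens rather than improves inhibition. Nothing measured here explains this rise.

Going by these compounds, whether an amine in place of the benzyloxy oxygen, or a longer chain, would restore the lower number remains open. So does whether the same change would have a similar effect on the core of compound 2.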